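A few compounds are considered here, and "the series" means these few. Any claim that something is new, unique, unknown or untested is made for them only; others in the source may bear on it.

In a functional assay on the whole organism (strain Sprague-Dawley) for inhibition, with Rattus norvegicus as the target, with a stated time of 10 min (on this read-out lower numbers stand for an effect already at smaller amounts and higher numbers for an effect only at larger amounts of compound), compound 1 `O=C(O)c1cnc(-c2ccccc2F)[nH]c1=O` gives 5 mg/kg. Compound 2 `O=C(O)c1cnc(-c2ccccc2[N+](=O)[O-])[nH]c1=O` carries a nitro in place of the fluoro on an aromatic carbon. For compound 2 the result in this assay is a limit of the assay, > 50 mg/kg. For the measured compounds named here, the one measured step, an at least 10-fold higher number from compound 1 to compound 2 (1.00 log units; beyond the scatter), thus ends at the limit of > 50 mg/kg in this assay, at which 1 of the 3 values shown sits. Compound 3 `CCOC(=O)c1cnc(-c2ccccc2[N+](=O)[O-])[nH]c1=O` is the ethyl ester of compound 2 and has no number of its own: in this assay compound 3 is recorded as "not determined" (no result reported). Its standing can only be guessed from the acid, and that value is a limit.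

Compound 4 `CCCCCOc1ccccc1-c1ncc(C(=O)OCC)c(=O)[nH]1` differs from compound 3 by pentyloxy in place of nitro on an aromatic carbon. Going by the values given here, no measured step covers this exchange. The step of an at least 10-fold higher number from compound 1 to compound 2 (1.00 log units; beyond the scatter) runs the other way, bringing a nitro in and pushing the dose up to a limit; it gives no guide to what a pentyloxy will do, and compound 3 offers no starting number. The direction and size of the change in this assay are therefore open. Compound 4 is expected to give roughly 20 mg/kg in this assay, inside a wide range from 3 mg/kg to 80 mg/kg, with a fair chance that only a limit is reported.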

Compound 4, dose for 50% inhibition: 2 mg/kg
Compound 4: the middle estimate sits 10-fold (1.00 log units) above what was measured; the whole stated range lies above it.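

For the compounds shown here, compound 3 has no number to compare in this assay, and so no step from it to compound 4 can be read. The compounds shown leave open what pentyloxy in place of nitro does on its own, and what the ethyl ester does compared with the free acid, for which compound 2 gives only a limit: the limit of > 50 mg/kg in this assay, at which 1 of the 4 values shown sits.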